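The source may report more compounds than this note shows. Statements on the series, on what has been measured and on what is new or still open speak of the compounds shown alone.

Measured so far in an assay on HeLa cells for inhibition of Indoleamine 2,3-dioxygenase 1 (Homo sapiens), read by spectrophotometry, with a stated time of 24 h; a lower number here means that less compound is needed, a higher number that more compound is needed for the effect:

compound 1, `[O-][S+]1CC(Nc2nonc2/C(=N/O)Nc2ccc(F)c(Br)c2)C1`: 79 nM
compound 2, `O=S(=O)(CCNc1nonc1/C(=N/O)Nc1ccc(F)c(Br)c1)N1CCC1`: 143 nM

Among the measured compounds shown here, compound 2 gives the higher of the two numbers in this assay, with compound 1 the nearest; the only measured step, a 1.8-fold higher number from compound 1 to compound 2 (0.26 log units; within the scatter), lies within the scatter, so the two compounds cannot be ordered on these data.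

Compound 3, `C#CCNS(=O)(=O)CCNc1nonc1/C(=N/O)Nc1ccc(F)c(Br)c1`, is not yet measured. It differs from compound 2 in one place: propargylamino in place of azetidin-1-yl on a sulfonyl sulfur. For the measured compounds named here, no measured step touches the sulfonyl sulfur; the one step available concerns the group on the aromatic nitrogen and was small, so it bears on this change only as a sign that the series has so far moved little. With nothing on the substituent of the sulfonyl sulfur, no step beyond the scatter is expected in this assay in either direction.

Compound 3 is therefore estimated at 150 nM, within 60 nM to 400 nM, which means an expected step of a 1.0-fold higher number from compound 2 to compound 3 (0.02 log units; within the scatter).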

Compound 3, half-maximal effective concentration: 33 nM
Compound 3: the middle estimate sits 4.5-fold (0.66 log units) above what was measured; measured number below the stated range.
By their numbers in this assay, from the lowest: compound 3; then compounds 1 and 2 (each within the scatter of the next).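

Among the compounds shown here, the substituent on the sulfonyl sulfur is not a silent position in this assay: propargylamino in place of azetidin-1-yl gives a 4.3-fold lower number from compound 2 to compound 3 (0.64 log units; beyond the scatter), the first step beyond the scatter, with the ring gone, a triple bond present and a hydrogen-bond donor added. The whole group on the aromatic nitrogen also gives a 2.4-fold lower number from compound 1 to compound 3 (0.38 log units; beyond the scatter), while a 1.8-fold higher number from compound 1 to compound 2 (0.26 log units; within the scatter) stays within the scatter, so what sits on the sulfonyl sulfur separates these two otherwise similar chains. Nothing available explains the drop in the number.

Still open, from the compounds shown here alone, is whether the lower number goes with the triple bond or with the hydrogen on the propargylamino nitrogen, which propylamino and N-methylpropargylamino on the sulfonyl sulfur would separate. Also open, going by these compounds, is whether the step carries over when chlorine replaces the bromine on the aromatic ring.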